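Closing an open amide into a pyrrolidine ring

The source may hold more compounds than are shown below. What is called first, only, known or untested is meant among the compounds shown, and "the series" means these compounds.

Three compounds share one core. Compound 1 `CNC(=O)CC1CCc2cc(OC)c(OC)cc21` gives 24.1% in a functional assay on the whole organism (strain Wistar) for inhibition, with Rattus norvegicus as the target, read by paw edema, with stated times of 60 min and 6 h, at a dose of 100 mg/kg by the oral route; on this read-out higher numbers stand for more inhibition at the one dose given (going by the name of the read-out) and lower numbers for less inhibition. Compound 2 `CCNC(=O)CC1CCc2cc(OC)c(OC)cc21` gives 20.4% in this assay, and compound 3 `CCCNC(=O)CC1CCc2cc(OC)c(OC)cc21` gives 22.2%. As a figure, the number of compound 2 is the smallest of the three, but the steps to its neighbours, a number 1.8 percentage points higher from compound 2 to compound 3 (within the scatter) and, in the other direction, a number 3.7 percentage points lower from compound 1 to compound 2 (within the scatter), both lie within the scatter, as does a number 1.9 percentage points lower from compound 1 to compound 3 (within the scatter).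

Compound 4 `COc1cc2c(cc1OC)C(CC(=O)N1CCCC1)CC2` differs from compound 2 in one place: pyrrolidin-1-yl in place of ethylamino on a carbonyl carbon. The measured steps all lengthen the chain on the amide-type nitrogen while keeping its hydrogen; none removes that hydrogen or closes a ring, so they bear on the new change only loosely. What they do show is that the numbers in this assay stay level across these alterations, without a step beyond the scatter. On that basis no step beyond the scatter is expected in this assay, and a number 0.6 percentage points higher from compound 2 to compound 4 (within the scatter) is the estimated change. Compound 4 is therefore expected to give about 21%, within a range from 8% to 34%.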

Compound 4, a percentage reported as inhibition, in the whole organism at one dose (the size of the read-out at that dose, not a potency): 22.2%
Beside the measured number, compound 4's estimate is 1.2 percentage points below it, within the range that was stated.
By their numbers in this assay, from the lowest: compounds 2, 3, 4 and 1 (each within the scatter of the next).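

Replacing an open chain on the carbonyl carbon with a ring that leaves no hydrogen-bond donor there does not move the read-out beyond the scatter in this assay: the steps are a number 1.8 percentage points higher from compound 2 to compound 4 (within the scatter), no change at the digits printed from compound 3 to compound 4 (within the scatter) and a number 1.9 percentage points lower from compound 1 to compound 4 (within the scatter). The earlier compounds shown here all kept the amide hydrogen, whereas compound 4 shows that, at this one dose, a group without it stands level with methylamino, ethylamino and propylamino. No measurement shown here gives a reason for this level result.

On these data alone, it remains open whether piperidin-1-yl, morpholin-4-yl or a hydroxyl group on the same carbonyl carbon would also stay level. As far as these compounds go, with every number taken at a single dose, it also remains open whether compound 4 and compound 2 would stay level at other doses.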